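The compounds below may be only part of what the source reports. "The series", "measured", "known", "first", "only" and "open" are said of these compounds alone.

Measured so far:
compound 1 `O=C(/C=C/c1ccccc1)NS(=O)(=O)c1ccc(Br)cc1` — 3.9 ug/mL
compound 2 `O=C(/C=C/c1ccc([N+](=O)[O-])cc1)NS(=O)(=O)c1ccccc1` — 4.8 ug/mL

Only these two numbers exist in a functional assay on B16-F10 cells (Mus musculus) for antiproliferative activity, read by ELISA and MTT assay, with a stated time of 48 h (on this read-out higher numbers stand for weaker inhibition and lower numbers for stronger inhibition), and compound 2 gives the higher of them; its nearest neighbour is compound 1, whose number lies within the usual scatter, so no order between the two can be read. Compound 3 `O=C(/C=C/c1ccc([N+](=O)[O-])cc1)NS(=O)(=O)c1ccc(Br)cc1` has not yet been measured in this assay. It differs from compound 2 by bromo in place of hydrogen on an aromatic carbon. Going by the values given here, no step between measured compounds bears on this change, and both measured values sit close together, so no step beyond the scatter is expected in either direction. Compound 3 is therefore expected near 3.8 ug/mL, in the range 1.9 ug/mL to 7.6 ug/mL, a step of a 1.3-fold lower number from compound 2 to compound 3 (0.10 log units; within the scatter) that is itself within the scatter.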

Compound 3, half-maximal inhibitory concentration: 13.9 ug/mL
Compound 3: the middle estimate sits 3.7-fold (0.56 log units) below what was measured; measured number above the stated range.
By their numbers in this assay, from the lowest: compounds 1 and 2 (each within the scatter of the next); then compound 3.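

In this assay, going by these compounds alone, bromo in place of hydrogen on an aromatic carbon, with nitro already present, gives a 2.9-fold higher number from compound 2 to compound 3 (0.46 log units; beyond the scatter) and is the first change to exceed the scatter. With bromo already present, adding nitro gives a 3.6-fold higher number from compound 1 to compound 3 (0.55 log units; beyond the scatter), so among these three compounds, weaker inhibition appears only with both groups together. Nothing on hand gives a reason for either step.

Still open, as far as these compounds go, is how the core carrying neither bromo nor nitro reads. It is also unknown whether an amine or a carboxylic acid in place of bromo would shift the number in the same direction.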